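Benzimidazole substitution next to the sulfonylcarbamate biaryl core

This account rests on a few compounds, and the source may have more. Where it says the series, first, only, none or still open, it means among the compounds named here.

Compound 2 `CCCCOC(=O)NS(=O)(=O)c1ccc(CCC)cc1-c1ccc(Cn2cnc3ccccc32)cc1` carries a hydrogen on the aromatic carbon between the two ring nitrogens of its fused ring system. Within the data shown here, in an assay on membranes from HEK293 cells for displacement of a labelled ligand from Type-2 angiotensin II receptor (Homo sapiens), read by radioligand binding (a higher number here means a weaker inhibitor, a lower number a stronger inhibitor), compound 2 gives 29 nM, the lowest of the two numbers measured so far; the nearest is compound 1 `CCCCOC(=O)NS(=O)(=O)c1ccc(CCC)cc1-c1ccc(Cn2c(-c3ccccc3)nc3ccccc32)cc1`, which in this assay gives 590 nM. Among the measured compounds shown here, the only measured step with the same point of change is a 20-fold lower number from compound 1 to compound 2 (1.31 log units; beyond the scatter), hydrogen in place of phenyl on that aromatic carbon: a large gain in potency on removing the aryl group.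

Compound 3 `CCCCOC(=O)NS(=O)(=O)c1ccc(CCC)cc1-c1ccc(Cn2c(Cc3ccccc3)nc3ccccc32)cc1` reverses that direction with a different group: benzyl in place of hydrogen on an aromatic carbon. For the measured compounds named here, no step with benzyl at this position has been measured, so the phenyl step is the only guide. A group of similar size entering the same place is expected to cost potency, though the single added carbon between the ring and the phenyl may soften the loss; compound 3 is therefore expected to show a 6.9-fold higher number from compound 2 to compound 3 (0.84 log units; beyond the scatter) in this assay. The estimate for compound 3 in this assay is 200 nM, within 60 nM to 700 nM.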

Compound 3, inhibition constant: 15 nM
Compound 3: middle estimate off by 13-fold (1.12 log units), on the high side, outside the stated range (below it).
By their numbers in this assay, from the lowest: compounds 3 and 2 (each within the scatter of the next); then compound 1.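

In this assay the aromatic carbon between two ring nitrogen atoms can carry a group with a six-membered aromatic ring without any change beyond the scatter, as a 1.9-fold lower number from compound 2 to compound 3 (0.29 log units; within the scatter) shows, so a ring-bearing group here does not by itself go with the high number of compound 1. What separates the two ring-bearing compounds is the single carbon that benzyl places between its ring and the aromatic carbon, and a 39-fold lower number from compound 1 to compound 3 (1.59 log units; beyond the scatter) makes this the largest step in the series, with benzyl in place of phenyl and the rest of the core unchanged. The available data give no basis for explaining why this one carbon matters so much.

Still open, on these data alone, is whether the same holds for a longer chain ending in phenyl, such as phenethyl, or for a link through an ether oxygen or an amine in place of the benzyl carbon. Equally open, as far as these compounds go, is whether a ring is needed at all, which a plain alkyl chain such as butyl, or a single methyl, at this carbon would address.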